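Adding a methoxycarbonyl group to a weak inhibitor

This account rests on a few compounds, and the source may have more. Where it says the series, first, only, none or still open, it means among the compounds named here.

Measured so far:
- compound 1, `Oc1ccc(CNc2cc(C(F)(F)F)cc3[nH]ncc23)c(Cl)c1`: 83%
- compound 2, `O=[N+]([O-])c1cccc(CNc2cc(Br)cc3[nH]ncc23)c1`: 72%
- compound 3, `O=[N+]([O-])c1ccccc1CNc1cccc2[nH]ncc12`: 25%

In an assay for inhibition of Indoleamine 2,3-dioxygenase 1 (Homo sapiens), with stated times of 10 min and 60 min, tested at 10 uM (on this read-out higher numbers stand for a stronger effect at the one concentration tested and lower numbers for a weaker effect), compound 3 gives 25%, the lowest of the three numbers; compound 2 and compound 1 both sit well beyond the scatter above it. Compound 4, `COC(=O)c1cc(NCc2ccccc2[N+](=O)[O-])c2cn[nH]c2c1`, has not been measured. It differs from compound 3 in one place: methoxycarbonyl in place of hydrogen on an aromatic carbon. Within the data shown here, no measured pair shows this exact change, so its effect is unknown. Compound 1 and compound 2 each carry a substituent on the same six-membered ring of the core and read higher than compound 3, yet they also differ in the other ring, so no single cause can be separated out. A modest rise is expected, with the step from compound 3 to compound 4 in this assay estimated at a number 13 percentage points higher from compound 3 to compound 4 (beyond the scatter). Compound 4 is therefore expected to give about 38%, within a range from 12% to 65%.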

Compound 4, a percentage reported as inhibition, at one concentration (the size of the read-out at that concentration, not a potency): 11%
For compound 4 the middle estimate is 27 percentage points above the measured one; measured number below the stated range.
By their numbers in this assay, from the lowest: compound 4; then compound 3; then compound 2; then compound 1.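

In this assay, methoxycarbonyl in place of hydrogen on this aromatic carbon gives a number 14 percentage points lower from compound 3 to compound 4 (beyond the scatter) as the effect of one single change. Among these compounds, this is the first direct reading at this position of the six-membered ring, and here the added group lowers the read-out rather than raising it. No measurement at hand explains the drop. As far as these compounds go, whether an amine or a carboxylic acid on the same carbon would also lower the read-out stays open. So does whether methoxycarbonyl would do the same on a compound other than compound 3.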